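The compounds below may be only part of what the source reports. "The series", "measured", "known", "first", "only" and "open" are said of these compounds alone.

Compound 1 `COc1ccc(/C=C\C(=O)O)c(OCc2cn(-c3ccccc3)nn2)c1CC=C(C)C` and its analogues were examined in a functional assay on A549 cells (Homo sapiens) for cytotoxicity, read by MTT assay, with a stated time of 24 h (a lower number here means a stronger inhibitor, a higher number a weaker inhibitor), where compound 1 gives 40500 nM. On the numbers shown, compound 1 holds the lowest of the two values, but only nominally: compound 3 `COc1ccc(/C=C\C(=O)O)c(OCc2cn(-c3nc4ccccc4s3)nn2)c1CC=C(C)C`, which carries a 1,3-benzothiazol-2-yl in place of the phenyl on the aromatic nitrogen, gives 42100 nM, and the step of a 1.0-fold higher number from compound 1 to compound 3 (0.02 log units; within the scatter) lies within the scatter. Compound 2 `COc1ccc(/C=C\C(=O)O)c(OCc2cn(-c3cccc(C#N)c3)nn2)c1CC=C(C)C`, bearing a nitrile on the same phenyl at another position, was entered in this assay, but for compound 2 the entry reads "not determined" (no result reported), so no result was reported for it.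

Compound 4 `COc1ccc(/C=C\C(=O)O)c(OCc2cn(-c3ccc(C#N)cc3)nn2)c1CC=C(C)C` differs from compound 1 as follows: cyano in place of hydrogen on an aromatic carbon. Within the data shown here, no measured step describes this change directly. Among the measured compounds shown here, the only step available, a 1.0-fold higher number from compound 1 to compound 3 (0.02 log units; within the scatter), shows that a far larger exchange on the aromatic nitrogen left the number essentially unchanged, which suggests that the substituent on that side of the molecule has little bearing on the read-out here. The smaller change toward compound 4 is therefore expected to move the number by no more than the scatter, with no clear direction, so the step of a 1.0-fold higher number from compound 1 to compound 4 (0.01 log units; within the scatter) is estimated to be negligible. Compound 4 is accordingly expected to give about 41000 nM in this assay, within a range of 20000 nM to 85000 nM.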

Compound 4, half-maximal inhibitory concentration: 42200 nM
Compound 4: the middle estimate sits 1.0-fold (0.01 log units) below what was measured, within the range that was stated.
By their numbers in this assay, from the lowest: compounds 1, 3 and 4 (each within the scatter of the next).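

In this assay, the change from phenyl to 4-cyanophenyl places a nitrile on an aromatic carbon, para to a large group, and gives a 1.0-fold higher number from compound 1 to compound 4 (0.02 log units; within the scatter), so substituting this ring, and not only exchanging it whole, leaves the number within the scatter. The step of a 1.0-fold higher number from compound 3 to compound 4 (0.00 log units; within the scatter) adds that 4-cyanophenyl and 1,3-benzothiazol-2-yl cannot be told apart here, which puts all three groups with a number on the aromatic nitrogen within the scatter of one another. Nothing available bears on the reason for this flat result.

Steps involving compound 2 cannot be read, so the compounds shown leave open whether the nitrile gives a similar number at another position on the phenyl, and whether an amine or a methoxy group at the position of the nitrile would move the number beyond the scatter. They also leave open whether the number responds to changes elsewhere on the core of compound 1, such as a methyl ester or an amide in place of the carboxylic acid.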